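A few compounds are considered here, and "the series" means these few. Any claim that something is new, unique, unknown or untested is made for them only; others in the source may bear on it.

Compound 1 `Cn1nc(-c2ccc(Cl)cc2)n(C)c1=S` gives 1.34 mg/kg in a functional assay on the whole organism with Mus musculus as the target (a lower number here means that less compound is needed, a higher number that more compound is needed for the effect), the lowest of the two numbers in hand. Chloro in place of hydrogen on an aromatic carbon gives compound 2 `Cn1nc(-c2ccc(Cl)c(Cl)c2)n(C)c1=S`, at 29 mg/kg; that step is a 22-fold higher number from compound 1 to compound 2 (1.34 log units; beyond the scatter). For compound 3 `CCn1c(-c2ccc(Cl)cc2)nn(C)c1=S` the result is a limit and not a number, > 50 mg/kg. Methyl in place of hydrogen on a saturated chain carbon bound to an aromatic nitrogen thus gives an at least 37-fold higher number from compound 1 to compound 3 (1.57 log units; beyond the scatter). Compound 4 `Cc1ccc(-c2nn(C)c(=S)n2C)cc1` differs from compound 1 by methyl in place of chloro on an aromatic carbon. Neither measured step swaps one group for another on the aromatic ring, yet both changes to compound 1 raised the number, so a modest rise is expected, a 2.6-fold higher number from compound 1 to compound 4 (0.42 log units; beyond the scatter). Compound 4 is therefore estimated at 3.5 mg/kg, with a range from 1 mg/kg to 15 mg/kg.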

Compound 4, dose for half-maximal effect: 1.74 mg/kg
The estimate for compound 4 lay 2.0-fold (0.30 log units) above the measured number; measured number inside the range.
By their numbers in this assay, from the lowest: compounds 1 and 4 (each within the scatter of the next); then compound 2. At a limit, above all of these: compound 3.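

In this assay, methyl in place of chloro on an aromatic carbon, para to a group of 8 heavy atoms, gives a 1.3-fold higher number from compound 1 to compound 4 (0.11 log units; within the scatter), so this position accepts the exchange with no shift beyond the scatter. Within the data shown here, both earlier steps raised the number far beyond the scatter, whereas this is the first change to the core of compound 1 that holds it. Nothing in hand gives a cause for this tolerance. As far as these compounds go, whether methoxy, an amine or a carboxylic acid would hold the number at this position stays open. So does the effect of a bare hydrogen there.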